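Swapping a trifluoromethoxy for a tert-butoxymethyl group

The compounds below may be only part of what the source reports. "The series", "measured", "known", "first", "only" and "open" are said of these compounds alone.

Of the compounds shown here, two sharing one core have been measured in a functional assay for agonist activity at G protein-coupled receptor 88 (Homo sapiens), read by HTRF and cAMP accumulation; on this read-out higher numbers stand for an effect only at larger amounts of compound and lower numbers for an effect already at smaller amounts. Compound 1 `CC[C@H](C)[C@H](N)CN(C(=O)[C@@H]1C[C@H]1c1ccccc1)c1ccc(-c2ccc(Oc3ccccc3)cc2)cc1` gives 94 nM in this assay, and compound 2 `CC[C@H](C)[C@H](N)CN(C(=O)[C@@H]1C[C@H]1c1ccccc1)c1ccc(-c2ccc(OC(F)(F)F)cc2)cc1` gives 170 nM. For the measured compounds named here, the only change between them, trifluoromethyl in place of phenyl on the oxygen, produced a 1.8-fold higher number from compound 1 to compound 2 (0.26 log units; within the scatter), so compound 2 and compound 1 sit within the scatter of each other and neither can be called the more potent.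

Compound 3 `CC[C@H](C)[C@H](N)CN(C(=O)[C@@H]1C[C@H]1c1ccccc1)c1ccc(-c2ccc(COC(C)(C)C)cc2)cc1` is not yet measured. It differs from compound 2 in one place: (tert-butoxy)methyl in place of trifluoromethoxy on an aromatic carbon. Going by the values given here, no measured step touches this exact change; the only step available, from compound 1 to compound 2, varied the same position without a shift beyond the scatter. On that basis compound 3 is expected to show a 1.2-fold higher number from compound 2 to compound 3 (0.07 log units; within the scatter) in this assay, with little real movement. The estimate for compound 3 is 200 nM, within a range from 60 nM to 700 nM.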

Compound 3, half-maximal effective concentration: 280 nM
Estimate against measurement, compound 3: 1.4-fold (0.15 log units) below; measured number inside the range.
By their numbers in this assay, from the lowest: compounds 1, 2 and 3 (each within the scatter of the next, the first and the last beyond it).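

At this position in this assay, the (tert-butoxy)methyl group, joined to the aromatic carbon through a carbon rather than an oxygen, cannot be told apart from trifluoromethoxy (a 1.6-fold higher number from compound 2 to compound 3 (0.22 log units; within the scatter)). Against phenoxy, however, it gives the first shift at this position that lies beyond the scatter, though only a modest one (a 3.0-fold higher number from compound 1 to compound 3 (0.47 log units; beyond the scatter)), while trifluoromethoxy remains within the scatter of both groups. Nothing available here explains this difference between phenoxy and (tert-butoxy)methyl.

Going by these compounds, it remains open how a plain tert-butyl group, with no oxygen in it, would compare with (tert-butoxy)methyl on this aromatic carbon. Also open, on these data alone, is how an amine, a carboxylic acid or a longer alkyl chain would read at the same place.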